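Benzyl in Place of Phenyl: What to Expect for Compound 4

The source may report more compounds than this note shows. Statements on the series, on what has been measured and on what is new or still open speak of the compounds shown alone.

Of the compounds shown here, three have been measured in a functional assay on MCF7 cells (Homo sapiens) for inhibition, read by sulforhodamine B assay, with a stated time of 48 h; on this read-out lower numbers stand for stronger inhibition of growth and higher numbers for weaker inhibition of growth. Compound 1 `O=C(CCl)NC(=O)Nc1ccc(Oc2ccccc2)cc1` gives 4200 nM. Compound 3 `O=C(CCl)NC(=O)Nc1ccc(OCc2ccccc2)cc1` differs from it by benzyl in place of phenyl on an oxygen on an aromatic ring and gives 4600 nM; this change produced a 1.1-fold higher number from compound 1 to compound 3 (0.04 log units; within the scatter). Compound 2 `O=C(CCl)NC(=O)Nc1cccc(Oc2ccccc2)c1` has the same atoms as compound 1 joined differently; the difference between the two cores is not broken down here. In this assay compound 2 gives 8100 nM, and its distances to compound 1 and to compound 3 both fall within the scatter, so no order among the three can be read from these numbers.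

Compound 4 `O=C(CCl)NC(=O)Nc1cccc(OCc2ccccc2)c1` is not yet measured. It relates to compound 2 as compound 3 relates to compound 1: benzyl in place of phenyl on an oxygen on an aromatic ring. The surroundings of the place are described in identical words in both cases, so this is the same change, now applied to the core of compound 2. Because the earlier step of a 1.1-fold higher number from compound 1 to compound 3 (0.04 log units; within the scatter) stayed within the scatter, compound 4 is expected to show a 1.1-fold higher number from compound 2 to compound 4 (0.04 log units; within the scatter). The estimate for compound 4 in this assay is 8900 nM, with a range from 4000 nM to 20000 nM.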

Compound 4, concentration for 50% growth inhibition: 6200 nM
Estimate against measurement, compound 4: 1.4-fold (0.16 log units) above, and the stated range covers the measured number.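

In this assay, benzyl in place of phenyl on an oxygen on an aromatic ring gives a 1.3-fold lower number from compound 2 to compound 4 (0.12 log units; within the scatter) on the second core. Set beside the earlier step, the change shows no difference between the two cores: the same change on two cores in this assay, a 1.1-fold higher number (0.04 log units; within the scatter) from compound 1 to compound 3 and a 1.3-fold lower number (0.12 log units; within the scatter) from compound 2 to compound 4, 1.4-fold (0.16 log units) apart, within the scatter of two such steps. This shows that on both cores the exchange leaves the number within the scatter, but it does not show that the change has any real effect or a direction, and two pairs of compounds say nothing about how it would behave on any other core in the series.

Going by these compounds, it remains open whether a longer chain such as phenylethyl on the same oxygen, or an amine or a carboxylic acid carried on the benzyl group, would move the number beyond the scatter. On these data alone, the chloroacetyl group is the same in all four compounds, so what an acetyl or a bromoacetyl group would do in its place is also open.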